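Saturating the allyl side chain: compound 3 to compound 4

The compounds below may be only part of what the source reports. "The series", "measured", "known", "first", "only" and "open" are said of these compounds alone.

Within the shared core, compound 1 `COc1ccc(-c2ccc(C(=O)N[C@H](C)CCCc3cccnc3)cc2Br)cc1OC` gives 180 nM in an assay (Canis lupus familiaris) for binding affinity to platelet-activating factor receptor (Homo sapiens), read by radioligand binding (on this read-out lower numbers stand for stronger inhibition and higher numbers for weaker inhibition), compound 2 `CCc1cc(C(=O)N[C@H](C)CCCc2cccnc2)ccc1-c1ccc(OC)c(OC)c1` gives 4 nM and compound 3 `C=CCc1cc(C(=O)N[C@H](C)CCCc2cccnc2)ccc1-c1ccc(OC)c(OC)c1` gives 80 nM. Compound 3 thus stands second highest of the three numbers, nearest to compound 1 and furthest from compound 2. Compound 4 `CCCc1cc(C(=O)N[C@H](C)CCCc2cccnc2)ccc1-c1ccc(OC)c(OC)c1` differs from compound 3 by ethyl in place of vinyl on a saturated chain carbon bound to an aromatic carbon. The step bearing directly on this is a 20-fold higher number from compound 2 to compound 3 (1.30 log units; beyond the scatter), which the present change reverses; a 45-fold lower number from compound 1 to compound 2 (1.65 log units; beyond the scatter) and a 2.3-fold lower number from compound 1 to compound 3 (0.35 log units; beyond the scatter) point the same way, ethyl over allyl. A large drop in this assay is therefore expected for compound 4, a 10-fold lower number from compound 3 to compound 4 (1.00 log units; beyond the scatter). Compound 4 is estimated at 8 nM, with a range of 2 nM to 30 nM.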

Compound 4, half-maximal inhibitory concentration: 50 nM
Compound 4: middle estimate off by 6.3-fold (0.80 log units), on the low side; measured number above the stated range.
By their numbers in this assay, from the lowest: compound 2; then compounds 4 and 3 (each within the scatter of the next); then compound 1.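

Replacing allyl with propyl leaves the number within the scatter (a 1.6-fold lower number from compound 3 to compound 4 (0.20 log units; within the scatter)), so in this assay the double bond does not separate these two compounds. One added methyl on the ethyl chain instead costs a large step (a 13-fold higher number from compound 2 to compound 4 (1.10 log units; beyond the scatter)), although propyl still keeps a modest gain over bromo (a 3.6-fold lower number from compound 1 to compound 4 (0.56 log units; beyond the scatter)). No measurement at hand accounts for this sharp dependence on the chain.

On these data alone, whether a methyl group or a cyclopropyl group at this place matches ethyl remains open. So does whether a butyl chain falls further than propyl.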